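Branching the acid side chain of compound 2

This account rests on a few compounds, and the source may have more. Where it says the series, first, only, none or still open, it means among the compounds named here.

Measured in a functional assay on a cell-free system (Platelet, plasma, Homo sapiens) for inhibition; a lower number here means a stronger inhibitor, a higher number a weaker inhibitor:
Compound 1 `O=C(O)CCN1Cc2ccc(NC(=O)c3ccc4c(c3)CNCC4)cc2C1=O` gives 1100 nM
Compound 2 `O=C(O)CN1Cc2ccc(NC(=O)c3ccc4c(c3)CNCC4)cc2C1=O` gives 120000 nM
Compound 3 `CC(CC(=O)O)N1Cc2ccc(NC(=O)CCCC3CCNCC3)cc2C1=O` gives 5400 nM

Compound 2 has the highest number of the three and is the weakest inhibitor here. Compound 4 `CC(CC(=O)O)N1Cc2ccc(NC(=O)c3ccc4c(c3)CNCC4)cc2C1=O` changes its side chain: 1-(carboxymethyl)ethyl in place of carboxymethyl on an amide-type nitrogen in a ring. Among the compounds with values here, the one measured step that bears on this is a 110-fold higher number from compound 1 to compound 2 (2.04 log units; beyond the scatter) (large), with carboxy in place of carboxymethyl on a saturated chain carbon. Compound 3, which also carries 1-(carboxymethyl)ethyl, gives 5400 nM with a different remainder. A large move to a lower number in this assay is therefore expected, opposite in direction to that step. The estimate expects a 150-fold lower number from compound 2 to compound 4 (2.18 log units; beyond the scatter) overall. For compound 4 the estimated value is 800 nM (150 nM to 5000 nM).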

Compound 4, half-maximal inhibitory concentration: 86 nM
Estimate against measurement, compound 4: 9.3-fold (0.97 log units) above, and the stated range ends above it.
By their numbers in this assay, from the lowest: compound 4; then compound 1; then compound 3; then compound 2.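

In this assay, within the data shown here, placing 1-(carboxymethyl)ethyl on the amide-type nitrogen gives a 1400-fold lower number from compound 2 to compound 4 (3.14 log units; beyond the scatter), a larger move at this position than the one step known before. Methyl on the saturated chain carbon also gives a 13-fold lower number from compound 1 to compound 4 (1.11 log units; beyond the scatter), which shows that the branch itself matters at this position, not only the length of the chain. Nothing measured here accounts for either step. As far as these compounds go, it remains open whether an ethyl or a phenyl group on that same carbon would lower the number further, and whether the two mirror-image forms of compound 4 differ.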